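The source may hold more compounds than are shown below. What is called first, only, known or untested is meant among the compounds shown, and "the series" means these compounds.

Measured compounds:
compound 1, `CCCNC(=O)C1C(C(=O)O)[C@@H]2CC[C@H]1O2`: 10000 nM
compound 2, `CCOC(=O)c1cn[nH]c1NC(=O)C1C(C(=O)O)[C@@H]2CC[C@H]1O2`: 10000 nM
compound 3, `O=C(O)C1C(C(=O)Nc2ccc(CO)cc2)[C@H]2CC[C@@H]1O2`: 10000 nM

These three compounds share one core and differ only in the group carried on the amide. In an ADME assay on SJ-G2 cells (Homo sapiens) for cytotoxicity, read by MTT assay, with a stated time of 72 h (on this read-out higher numbers stand for weaker inhibition of growth and lower numbers for stronger inhibition of growth), compound 1 gives 10000 nM. Compound 2 gives 10000 nM and compound 3 gives 10000 nM in this assay. Compound 1 thus stands level with compounds 2 and 3 at the digits reported: the nearest, compound 2, shows no change at those digits and lies within the scatter, and the furthest, compound 3, also shows no change at those digits. No two of these compounds differ in only one place, so no single step between measured compounds can be read from them.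

Compound 4, `CCCCCCCCNC(=O)C1C(C(=O)O)[C@@H]2CC[C@H]1O2`, has not yet been measured in this assay. It differs from compound 1 in one place: pentyl in place of hydrogen on a saturated chain carbon, three bonds along the chain from an amide-type nitrogen. The measured compounds give no hint of movement in either direction, and the step expected from this change, a 1.4-fold lower number from compound 1 to compound 4 (0.15 log units; within the scatter), is small, within the scatter, with at most a slight lean toward stronger inhibition of growth. Compound 4 is estimated to give 7000 nM, with a range from 2500 nM to 10000 nM.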

Compound 4, concentration for 50% growth inhibition: 10000 nM
Estimate against measurement, compound 4: 1.4-fold (0.15 log units) below; measured number inside the range.
By their numbers in this assay, from the lowest: compounds 1, 2, 3 and 4 (each within the scatter of the next).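

With pentyl in place of hydrogen on a saturated chain carbon, three bonds along the chain from an amide-type nitrogen, this assay shows no change at the digits printed from compound 1 to compound 4 (within the scatter). Within the data shown here, this is the first pair of measured compounds that differ in one place, so the effect of a single change can now be read directly, rather than only seen as similar numbers across compounds with different amide groups. At this position, this added stretch of saturated carbon leaves the number where it stood, and no available measurement offers an explanation for that.

These compounds cannot show whether a different group at the same chain carbon, such as an amine or a carboxylic acid, would shift the number in this assay. Among these compounds, they also leave open whether a chain longer than the one in compound 4 would shift it, and whether any change elsewhere on the shared core would do so.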